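A 4-hydroxyphenyl swap on compound 1

The compounds below may be only part of what the source reports. "The series", "measured", "known", "first", "only" and "open" are said of these compounds alone.

Compound 1 `COc1ccc(-c2cnc(NC(=O)c3cnc[nH]3)n2C)cc1` gives > 100000 nM
Compound 2 `Cn1c(-c2ccccc2F)cnc1NC(=O)c1ccc(F)cc1` gives > 100000 nM
Compound 3 `CCCn1c(-c2ccc(OC)cc2)cnc1NC(=O)c1ccc(F)cc1` gives > 100000 nM

In a toxicity assay on THP-1 cells (Homo sapiens) for inhibition (a higher number here means that more compound is tolerated, a lower number that less compound is tolerated), compound 1 gives > 100000 nM as a limit of the assay, not as a number. Compound 1 shares that position with compound 2 and compound 3, which leaves the limit of > 100000 nM in this assay, at which 3 of the 3 values shown sit, as the whole of the record so far.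

Compound 4 `COc1ccc(-c2cnc(NC(=O)c3ccc(O)cc3)n2C)cc1` keeps the core of compound 1 and carries 4-hydroxyphenyl in place of 1H-imidazol-5-yl on a carbonyl carbon.

No change beyond the usual scatter is expected in this assay because the limit of > 100000 nM in this assay, at which 3 of the 3 values shown sit, offers no measured number for compound 1 or for any other compound. The expected move is a number no higher from compound 1 to compound 4 (the limit leaves the size open) in the estimate made here. The estimated value for compound 4 is 100000 nM with an expected range of 40000 nM to 200000 nM and a strong expectation that the assay again reports only a limit.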

Compound 4, half-maximal cytotoxic concentration: > 100000 nM
Compound 4: a limit, no number; the forecaster's own chance of this, stated with the estimate: 85%; the middle value sits exactly at the limit.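

In this assay, within the data shown here, compound 1 and compound 4 both give only a limit and no number, so no step between them can be read: the limit of > 100000 nM in this assay, at which 4 of the 4 values shown sit. The compounds shown leave open where the half-maximal cytotoxic concentration of any of them lies, and whether 4-hydroxyphenyl in place of 1H-imidazol-5-yl shifts it at all.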